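Methyl in Place of Hydrogen: From Compound 1 to Compound 4

The source may hold more compounds than are shown below. What is called first, only, known or untested is meant among the compounds shown, and "the series" means these compounds.

Compound 1, `Nc1ccccc1NC(=O)c1ccc(CSC(=S)N2CCN(c3ccccc3)CC2)cc1`: 87.4%
Compound 2, `Nc1ccccc1NC(=O)c1ccc(CSC(=S)N2CCc3cc(Cl)ccc32)cc1`: 82.2%
Compound 3, `CC1CCCCN1C(=S)SCc1ccc(C(=O)Nc2ccccc2N)cc1`: 86.9%

In a functional assay on MGC-803 cells (Homo sapiens) for antiproliferative activity, read by CCK-8 assay, with a stated time of 72 h, tested at 8 uM (on this read-out higher numbers stand for a stronger effect at the one concentration tested and lower numbers for a weaker effect), compound 1 gives 87.4%, the highest of the three numbers shown. Its nearest neighbour is compound 3 with 86.9%, a gap within the scatter, and its furthest is compound 2 with 82.2%, also within the scatter. With every gap inside the scatter, none of the three can be called the most active.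

Only one measured step joins two of these compounds: a number 4.7 percentage points higher from compound 2 to compound 3 (within the scatter). That exchange sits on the thiocarbonyl carbon and moves the read-out by less than the scatter.

Compound 4, `Cc1ccc(N2CCN(C(=S)SCc3ccc(C(=O)Nc4ccccc4N)cc3)CC2)cc1`, differs from compound 1 in one place: methyl in place of hydrogen on an aromatic carbon. Within the data shown here, no measured step touches this aromatic ring, so the one step in hand bears on it only loosely, by showing that a change at the other end of the shared core left the number where it was. The three compounds all cluster high, and the change from hydrogen to methyl is small. Compound 4 is therefore expected to give a step of a number 2.4 percentage points lower from compound 1 to compound 4 (within the scatter), not beyond the scatter. The estimate for compound 4 is 85%, with a range from 74% to 93%.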

Compound 4, a percentage reported as inhibition, at one concentration (the size of the read-out at that concentration, not a potency): 19.8%
The estimate for compound 4 lay 65.2 percentage points above the measured number, outside the stated range (below it).
By their numbers in this assay, from the lowest: compound 4; then compounds 2, 3 and 1 (each within the scatter of the next).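

In this assay, the change from phenyl to 4-methylphenyl gives a number 67.6 percentage points lower from compound 1 to compound 4 (beyond the scatter), so adding a single methyl para to a large group is enough to take the read-out from the high cluster to far below it. Among these compounds, the one earlier step, a number 4.7 percentage points higher from compound 2 to compound 3 (within the scatter), concerned a different exchange on the thiocarbonyl carbon and gave no warning of this; the phenyl ring of compound 1 now emerges as a place where the smallest of additions can matter a great deal at the one concentration tested. Nothing shown gives a cause for this loss.

On these data alone, whether the loss belongs to methyl in particular or would follow any group on this aromatic carbon remains open, and a fluorine, a chlorine or a methoxy group there would begin to separate those two readings. As far as these compounds go, it also remains open whether the same methyl on another carbon of this ring would bring a comparable loss, and whether the gap would persist at other concentrations, since a single-concentration read-out is not a potency.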